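The source may report more compounds than this note shows. Statements on the series, on what has been measured and on what is new or still open speak of the compounds shown alone.

Working notes on the series in a physicochemical assay for lipophilicity, using the shake flask method, in phosphate buffer, measured as octanol-water partition, at pH 7.4; a higher number here means a more lipophilic compound, a lower number a more polar compound.

Three compounds share one core and differ only in the group on the amide-type nitrogen. Compound 1 `COc1cc(-c2cc(C(=O)O)c3ccccc3n2)ccc1OCC(=O)Nc1ccccc1` gives 0.7. Compound 2 `COc1cc(-c2cc(C(=O)O)c3ccccc3n2)ccc1OCC(=O)Nc1ccc(C)cc1` gives 1.2. Compound 3 `COc1cc(-c2cc(C(=O)O)c3ccccc3n2)ccc1OCC(=O)Nc1ccc(Cl)cc1` gives 1.5.

Compound 2 stands second highest of the three numbers: the step of a number 0.50 log units higher from compound 1 to compound 2 (beyond the scatter) is beyond the scatter, while compound 3 lies a number 0.30 log units higher from compound 2 to compound 3 (within the scatter), within the scatter, so compounds 2 and 3 cannot be ordered. The step of a number 0.80 log units higher from compound 1 to compound 3 (beyond the scatter) is also beyond the scatter.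

The next compound is compound 4 `COc1cc(-c2cc(C(=O)O)c3ccccc3n2)ccc1OCC(=O)NC1CCCCC1`. Its difference from compound 2 is cyclohexyl in place of 4-methylphenyl on an amide-type nitrogen. Among the measured compounds shown here, none of the measured steps bears directly on this change: all three exchange one substituent on an aromatic carbon, and none replaces the aromatic ring itself by a non-aromatic one. The measured steps give no guidance on direction here, so no step beyond the scatter is expected in this assay, and the estimate is placed at the value of compound 2 with a wide range.

Compound 4 is therefore expected at 1.2, between 0.6 and 1.8, which would mean an expected step of no change at the digits printed from compound 2 to compound 4 (within the scatter).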

Compound 4, distribution coefficient: 0.8
Estimate against measurement, compound 4: 0.40 log units above; the measured number falls inside the stated range.
By their numbers in this assay, from the lowest: compounds 1 and 4 (each within the scatter of the next); then compounds 2 and 3 (each within the scatter of the next).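

In this assay this position on the amide-type nitrogen responds to replacing the aromatic ring itself, and not only to exchanging a substituent on it: cyclohexyl in place of 4-methylphenyl gives a number 0.40 log units lower from compound 2 to compound 4 (beyond the scatter) and cyclohexyl in place of 4-chlorophenyl gives a number 0.70 log units lower from compound 3 to compound 4 (beyond the scatter) as the corresponding step. The outcome depends on which aromatic group leaves, since cyclohexyl in place of phenyl gives a number 0.10 log units higher from compound 1 to compound 4 (within the scatter) and so places cyclohexyl level with the unsubstituted phenyl, while only the two substituted phenyl groups stand apart from it. No measurement shown here speaks to the origin of this difference.

The compounds shown leave open whether a substituted saturated ring such as 4-methylcyclohexyl would stand with compound 4 or move as far as the methyl step on the aromatic ring did. They also leave open where an open chain such as hexyl, or a ring carrying an amine, would fall at this position on the amide-type nitrogen.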